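Benzyl-bearing series: formyl swap at the aryl position

The source may report more compounds than this note shows. Statements on the series, on what has been measured and on what is new or still open speak of the compounds shown alone.

Going by the values given here, compound 3 `Cc1cccc(-c2cn3ccnc3c(-c3ccc4ncn(Cc5ccccc5)c4c3)n2)c1` has the lowest number of the three compounds measured so far in a functional assay on SR cells (Homo sapiens) for inhibition, read by sulforhodamine B assay, with a stated time of 48 h, tested at 10 uM; a higher number here means more inhibition at the concentration tested (going by the name of the read-out), a lower number less inhibition: compound 3 gives 11%, while compound 2 `CCc1ccc(-c2cn3ccnc3c(-c3ccc4ncn(Cc5ccccc5)c4c3)n2)cc1` gives 49.9% and compound 1 `O=Cc1ccc(-c2cn3ccnc3c(-c3ccc4ncn(C5CCCCC5)c4c3)n2)cc1` gives 47.5%. Compound 4 `O=Cc1ccc(-c2cn3ccnc3c(-c3ccc4ncn(Cc5ccccc5)c4c3)n2)cc1` is the next step from compound 3, with 4-formylphenyl in place of 3-methylphenyl on an aromatic carbon.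

Among the compounds with values here, one measured step bears on this change. The step of a number 38.9 percentage points lower from compound 2 to compound 3 (beyond the scatter) shows that moving from 4-ethylphenyl to 3-methylphenyl on the benzyl-bearing core costs most of the inhibition. Compound 1 carries the same 4-formylphenyl that enters here, on a core differing only in its cyclohexyl group, and compound 1 gives 47.5% in this assay, near the number for compound 2. Taken together, replacing 3-methylphenyl with 4-formylphenyl is expected to reverse most of the loss seen in compound 3, with an expected step of a number 34 percentage points higher from compound 3 to compound 4 (beyond the scatter). Compound 4 is therefore estimated at 45% in this assay, with a range from 25% to 65%.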

Compound 4, a percentage reported as inhibition, at one concentration (the size of the read-out at that concentration, not a potency): 47.5%
Compound 4: the middle estimate sits 2.5 percentage points below what was measured; measured number inside the range.
By their numbers in this assay, from the lowest: compound 3; then compounds 1, 4 and 2 (each within the scatter of the next).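

In this assay, 4-formylphenyl on the benzyl-bearing core gives a number 36.5 percentage points higher from compound 3 to compound 4 (beyond the scatter), so the low number of compound 3 does not hold for every aryl group at this position on that core. Formyl and ethyl on the phenyl ring are not told apart on this core, with a number 2.4 percentage points lower from compound 2 to compound 4 (within the scatter) as the reading for that swap. With 4-formylphenyl in place, the group on the aromatic nitrogen is also not told apart, as no change at the digits printed from compound 1 to compound 4 (within the scatter) for benzyl in place of cyclohexyl.

Going by these compounds, compound 3 and compound 4 differ in both the substituent and where it sits on the phenyl ring, so 4-methylphenyl or 3-formylphenyl would be needed to separate the two, and an amine or a carboxylic acid in place of formyl remains open. Nothing available speaks to the cause of these steps.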